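A few compounds are considered here, and "the series" means these few. Any claim that something is new, unique, unknown or untested is made for them only; others in the source may bear on it.

Compound 1 `COC(=O)c1c(-c2ccc(C(=O)N(c3ncccc3C)[C@@H]3CCCNC3)cc2)cnn1C` gives 2500 nM in an assay on THP-1 cells for inhibition of Proprotein convertase subtilisin/kexin type 9 (Homo sapiens), read by AlphaLISA; on this read-out lower numbers stand for stronger inhibition and higher numbers for weaker inhibition. Compound 2 `CNc1cncc(-c2ccc(C(=O)N(c3ncccc3Cl)[C@@H]3CCCNC3)cc2)n1` gives 3100 nM in this assay.

Compound 2 has the highest of the two numbers, though its number and that of compound 1 lie within the usual scatter of each other. Compound 3 `CN(C)c1cncc(-c2ccc(C(=O)N(c3ncccc3Cl)[C@@H]3CCCNC3)cc2)n1` differs from compound 2 in one place: methyl in place of hydrogen on a nitrogen on an aromatic ring. For the measured compounds named here, no measured pair shows this kind of step, so no size can be taken from the data; a change of about the scatter, with no clear direction, is expected, as a 1.1-fold higher number from compound 2 to compound 3 (0.05 log units; within the scatter). Compound 3 is therefore estimated at 3500 nM in this assay, with a range from 1400 nM to 9000 nM.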

Compound 3, half-maximal inhibitory concentration: 3000 nM
Beside the measured number, compound 3's estimate is 1.2-fold (0.07 log units) above it; the range from low to high includes it.
By their numbers in this assay, from the lowest: compounds 1, 3 and 2 (each within the scatter of the next).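

For the compounds shown here, the step from the methylamino to the dimethylamino group reads a 1.0-fold lower number from compound 2 to compound 3 (0.01 log units; within the scatter) in this assay and is the first measured step at this nitrogen on the aromatic ring. It shows that, on this pair, the position accepts methyl in place of hydrogen with the two numbers staying within the scatter of each other. Nothing shown bears on why this is so. Still open, going by these compounds, is whether a larger group on this nitrogen, such as ethyl or a morpholine ring, would give a number within the scatter too. Also open, on these data alone, is what a plain amino group would give here.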